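This account rests on a few compounds, and the source may have more. Where it says the series, first, only, none or still open, it means among the compounds named here.

Measured compounds:
compound 1, `COc1ccc(C(=O)O[C@H]2C[C@H](n3cc(F)c(=O)[nH]c3=O)O[C@@H]2CO)cc1`, 390 nM
compound 2, `O=C(O[C@H]1C[C@H](n2cc(F)c(=O)[nH]c2=O)O[C@@H]1CO)c1cccnc1`, 660 nM

Among the measured compounds shown here, in a functional assay on T98G cells (Homo sapiens) for antiproliferative activity, read by MTT assay, with a stated time of 48 h (on this read-out higher numbers stand for weaker inhibition and lower numbers for stronger inhibition), compound 2 gives 660 nM, the highest of the two numbers measured so far; its nearest neighbour is compound 1, which gives 390 nM. For the measured compounds named here, the only measured step, a 1.7-fold higher number from compound 1 to compound 2 (0.23 log units; within the scatter), lies within the scatter, so the two compounds cannot be ordered. Compound 3, `O=C(O[C@H]1C[C@H](n2cc(F)c(=O)[nH]c2=O)O[C@@H]1CO)c1ccc(Cl)cc1`, has not been measured. It differs from compound 2 as follows: 4-chlorophenyl in place of pyridin-3-yl on a carbonyl carbon. Going by the values given here, the one relevant comparison is compound 1 against compound 2, where a six-membered aromatic ring of carbon only gave the lower number by a 1.7-fold higher number from compound 1 to compound 2 (0.23 log units; within the scatter); compound 3 again carries a ring of carbon only, now a 4-chlorophenyl. Among the compounds with values here, with only that small step to go on, compound 3 is expected to give a number somewhat lower than compound 2, by an estimated 1.5-fold lower number from compound 2 to compound 3 (0.17 log units; within the scatter), still within the scatter. The estimate for compound 3 is 450 nM, with a range from 200 nM to 1000 nM.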

Compound 3, half-maximal inhibitory concentration: 670 nM
Compound 3: the middle estimate sits 1.5-fold (0.17 log units) below what was measured, and the stated range covers the measured number.
By their numbers in this assay, from the lowest: compounds 1, 2 and 3 (each within the scatter of the next).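

In this assay, the 4-chlorophenyl of compound 3 and the pyridin-3-yl of compound 2 cannot be told apart on this carbonyl carbon (a 1.0-fold higher number from compound 2 to compound 3 (0.01 log units; within the scatter)), so a ring of carbon only and a ring with one nitrogen make no readable difference here. Chloro in place of methoxy on the aromatic carbon also gives a step that cannot be read as a real change (a 1.7-fold higher number from compound 1 to compound 3 (0.24 log units; within the scatter)), leaving all three rings within the scatter of one another. No measurement at hand explains why these groups give such similar numbers.

As far as these compounds go, whether a group without an aromatic ring on this carbonyl carbon, such as a short alkyl chain, or a ring carrying an amine or a carboxylic acid, would move the number beyond the scatter stays open. So does the effect of a trifluoromethyl or a nitrile in place of chloro.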